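The source may hold more compounds than are shown below. What is called first, only, known or untested is meant among the compounds shown, and "the series" means these compounds.

Of the compounds shown here, three have so far been tested in a functional assay on PC-3 cells (Homo sapiens) for cytotoxicity, read by MTT assay, with a stated time of 72 h; on this read-out lower numbers stand for stronger inhibition of growth and higher numbers for weaker inhibition of growth. Compound 2 `CS/C(=N\C(=O)c1cccs1)NC(=O)c1cccs1` gives 98300 nM there. Compound 1 `O=C(/N=C(/NC(=O)c1cccs1)[Se]Cc1ccccc1)c1cccs1` reaches only a limit of the assay, > 100000 nM. The step of an at least 1.0-fold higher number from compound 2 to compound 1 (0.00 log units; that floor lies within the scatter) corresponds to the change (a group of 8 heavy atoms (7 carbon, 1 selenium; one six-membered aromatic ring of carbon only) in place of a group of 2 heavy atoms (1 carbon, 1 sulfur; no ring), on a carbon with a double bond to nitrogen). Compound 3 `CS/C(=N\C(=O)c1cnc2ccccc2c1)NC(=O)c1cnc2ccccc2c1` likewise reaches only a limit, > 100000 nM. How the core of compound 3 differs from the core of compound 2 is not broken down here. Compound 4 `O=C(/N=C(/NC(=O)c1cnc2ccccc2c1)[Se]Cc1ccccc1)c1cnc2ccccc2c1` carries the same change, made on the core of compound 3: a group of 8 heavy atoms (7 carbon, 1 selenium; one six-membered aromatic ring of carbon only) in place of a group of 2 heavy atoms (1 carbon, 1 sulfur; no ring), on a carbon with a double bond to nitrogen. The measured results cluster at the limit of > 100000 nM in this assay, at which 2 of the 3 values shown sit. The step from compound 3 to compound 4 is expected to be a step that the limit leaves unreadable from compound 3 to compound 4, resting on the earlier step of an at least 1.0-fold higher number from compound 2 to compound 1 (0.00 log units; that floor lies within the scatter), which gave no gain. Compound 4 is therefore expected to give 150000 nM in this assay, most likely again as a limit, between 80000 nM and 400000 nM.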

Compound 4, concentration for total growth inhibition: > 100000 nM
Compound 4: a limit, no number (the forecaster's own chance of this, stated with the estimate: 85%); the middle value does not contradict the limit.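

Compound 3 and compound 4 each give only a limit in this assay, and the step between them cannot be read. The compounds shown leave open whether putting the selenium-containing group in place of methylsulfanyl changes growth inhibition on this core at all.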